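This account rests on a few compounds, and the source may have more. Where it says the series, first, only, none or still open, it means among the compounds named here.

Compound 1 `O=C(c1ccccc1)c1sc(N2CCCC2)nc1Br`: in a functional assay on SK-MEL-28 cells (Homo sapiens) for cytotoxicity, read by MTT assay, with a stated time of 72 h (on this read-out lower numbers stand for stronger inhibition and higher numbers for weaker inhibition), compound 1 gives > 100000 nM, which is a limit of the assay rather than a number.
Compound 2 `O=C(c1ccccc1)c1sc(N2CCCCC2)nc1Br`: in this assay compound 2 gives 91000 nM.
Compound 3 `COC(=O)c1sc2nc(N3CCCC3)sc2c1C`: in this assay compound 3 gives > 100000 nM, again a limit of the assay and not a number.

Compounds 1 and 2 share one core and differ in a single place: piperidin-1-yl in place of pyrrolidin-1-yl on an aromatic carbon. That change produced an at least 1.0-fold lower number from compound 1 to compound 2 (0.04 log units; that floor lies within the scatter), so the two results cannot be told apart, and both lie close to the limit of > 100000 nM in this assay, at which 2 of the 3 values shown sit. Compound 3 is built on another core, and the difference between the two cores is not broken down here. Compound 4 `COC(=O)c1sc2nc(N3CCCCC3)sc2c1C`, not yet measured, arises from compound 3 by the same kind of change, (piperidin-1-yl in place of pyrrolidin-1-yl on an aromatic carbon). The surroundings are not identical: in compound 4 the ring carrying the change is part of a fused or bridged system of two rings, whereas in compound 1 the place lies two ring bonds from the ring atom that bears a bromo group and two ring bonds from the ring atom that bears a group of 8 heavy atoms. For compound 4 the expected step is a number no higher from compound 3 to compound 4 (the limit leaves the size open), because an at least 1.0-fold lower number from compound 1 to compound 2 (0.04 log units; that floor lies within the scatter) stayed within the scatter. The estimate for compound 4 in this assay is 100000 nM, with a likely range from 50000 nM to 200000 nM, and a limit rather than a number is quite possible.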

Compound 4, half-maximal inhibitory concentration: > 100000 nM
Compound 4 gave a limit, no number; the forecaster's own chance of this, stated with the estimate: 60%; the middle value lies on the limit itself.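

Compound 3 and compound 4 each give only a limit of the assay, and the step between them cannot be read. The results now gather at a single point: the limit of > 100000 nM in this assay, at which 3 of the 4 values shown sit. The compounds shown leave open whether piperidin-1-yl in place of pyrrolidin-1-yl changes anything on the core of compound 3 in this assay.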